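Butoxy in place of benzyl on a shared core

The source may report more compounds than this note shows. Statements on the series, on what has been measured and on what is new or still open speak of the compounds shown alone.

Of the compounds shown here, two built on one core have been tested in a functional assay on BT-549 cells (Homo sapiens) for inhibition, read by sulforhodamine B assay, with a stated time of 48 h; on this read-out lower numbers stand for stronger inhibition of growth and higher numbers for weaker inhibition of growth. Compound 1 `O=C(Nc1ccc(Cc2ccccc2)cc1)Nc1nn(C(=O)Nc2ccc(Cc3ccccc3)cc2)c2ccccc12` carries two urea arms. For compound 1 the read-out is a limit of the assay, > 100000 nM, and not a number. Compound 2 `Nc1nn(C(=O)Nc2ccc(Cc3ccccc3)cc2)c2ccccc12` keeps one urea arm and bears a free amine on the core. In this assay compound 2 gives 13500 nM. Going by the values given here, compound 2 therefore stands as the only real number in hand; the other entry is the limit of > 100000 nM in this assay, at which 1 of the 2 values shown sits.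

Compound 3 `CCCCOc1ccc(NC(=O)n2nc(N)c3ccccc32)cc1` has not yet been measured. It differs from compound 2 in one place: butoxy in place of benzyl on an aromatic carbon. Among the compounds with values here, no pair of measured compounds differs in only one place, so no measured step shows how such a change moves the read-out. The expectation for this assay is a shift that stays within the usual scatter, with the estimated step coming out as a 1.1-fold higher number from compound 2 to compound 3 (0.05 log units; within the scatter). On that basis compound 3 is expected to give 15000 nM, with a likely range from 5000 nM to 45000 nM.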

Compound 3, concentration for 50% growth inhibition: 14000 nM
Compound 3: the middle estimate sits 1.1-fold (0.03 log units) above what was measured, and the stated range covers the measured number.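

In this assay, butoxy in place of benzyl on an aromatic carbon, para to a large group, gives a 1.0-fold higher number from compound 2 to compound 3 (0.02 log units; within the scatter), so the two compounds cannot be told apart on this read-out. Going by these compounds alone, this is the first step that changes only one place, and it gives this position its first direct comparison: a six-membered aromatic ring of carbon only leaves, a chain with no ring and one oxygen enters, and the read-out stays within the scatter. So at this position, on this core, the benzyl ring is not needed to keep growth inhibition at the level of compound 2, although nothing measured here explains why the two groups read alike.

The compounds shown leave open how a carboxylic acid, an amine or a longer chain would read at this same position. With a single step at a single position, they also leave open whether butoxy and benzyl would still match if the free amine on the shared core were replaced by another group.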